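A few compounds are considered here, and "the series" means these few. Any claim that something is new, unique, unknown or untested is made for them only; others in the source may bear on it.

The evidence here rests on a single number. For the measured compounds named here, in a functional assay on HL-60 cells (Homo sapiens) for antiproliferative activity, read by resazurin assay, with a stated time of 24 h (on this read-out lower numbers stand for stronger inhibition and higher numbers for weaker inhibition), compound 1 (`CCCCCCCCCCCCC/C=C/C(=O)[C@H](CO)NC(C)=O`) gives 43000 nM as the only measured value. In this assay compound 2 (`CCCCCCCCc1ccc(/C=C/C(=O)[C@H](CO)NC(C)=O)cc1`) has no result reported and therefore no number of its own. Compound 3 (`CC(=O)N[C@@H](CO)C(=O)/C=C/c1ccccc1`) has yet to be measured. The structural change is hydrogen in place of octyl on an aromatic carbon and it places hydrogen in place of octyl on an aromatic carbon, para to a large group. Going by the values given here, no step between measured compounds is available to size this change. A moderate step toward higher numbers in this assay is nevertheless expected, somewhat beyond the scatter, with compound 1 at (43000 nM) as the only reference point. For compound 3 the estimated value is 80000 nM with an expected range (25000 nM to 250000 nM).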

Compound 3, half-maximal inhibitory concentration: 48000 nM
Compound 3: middle estimate off by 1.7-fold (0.22 log units), on the high side, within the range that was stated.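

No new step can be read from this result: in this assay compound 3 gives 48000 nM and compound 2 has no number to set against it. No supporting evidence bears on this result. The compounds shown leave open what the octyl group changes in this assay.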